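Cyano on the phenyl of a thiazole acetic acid

The source may hold more compounds than are shown below. What is called first, only, known or untested is meant among the compounds shown, and "the series" means these compounds.

Among the measured compounds shown here, compound 1 `O=C(O)Cc1sc(C(c2ccc(F)cc2)c2ccc(F)cc2)nc1-c1ccccc1` gives 16 nM in an in vitro assay on HEK385-7 cells for displacement of a labelled ligand from prostaglandin D2 receptor 2 (Homo sapiens) (a lower number here means a stronger inhibitor, a higher number a weaker inhibitor), the highest of the two numbers so far, though compound 2 `O=C(O)Cc1sc(C(c2ccccc2)c2ccc(Cl)cc2)nc1-c1ccc(F)cc1` with 14 nM lies within the scatter of it. For the measured compounds named here, no step between the measured compounds is at hand, so nothing yet shows how a substituent here shifts potency. Compound 3 `N#Cc1ccc(-c2nc(C(c3ccc(F)cc3)c3ccc(F)cc3)sc2CC(=O)O)cc1` carries the change (cyano in place of hydrogen on an aromatic carbon), cyano in place of hydrogen on an aromatic carbon. The step is expected to stay close to the scatter, a 1.3-fold lower number from compound 1 to compound 3 (0.12 log units; within the scatter), with no strong direction. Compound 3 is therefore estimated at 12 nM, between 4 nM and 40 nM.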

Compound 3, half-maximal inhibitory concentration: 150 nM
Compound 3: the middle estimate sits 13-fold (1.10 log units) below what was measured; measured number above the stated range.
By their numbers in this assay, from the lowest: compounds 2 and 1 (each within the scatter of the next); then compound 3.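

Among the compounds shown here, the first single-place change here, phenyl to 4-cyanophenyl, gives a 9.4-fold higher number from compound 1 to compound 3 (0.97 log units; beyond the scatter). This aromatic carbon is therefore not indifferent to substitution: with a cyano on it, the shared core becomes a weaker inhibitor, which compound 1 and compound 2 alone could not show. Nothing at hand bears on why the step is this large.

Going by these compounds, whether a methoxy group, a chlorine atom or an amine on the same carbon would cost as much stays open. So does whether a cyano elsewhere on this ring would behave alike.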